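Amino substitution on two cores of a cytotoxic series

A few compounds are considered here, and "the series" means these few. Any claim that something is new, unique, unknown or untested is made for them only; others in the source may bear on it.

Compound 1 `CCn1cc(-c2nc3ccccc3[nH]2)c(=O)c2cc(F)c(N3CCNCC3)cc21` and compound 2 `CCn1cc(-c2nc3ccccc3[nH]2)c(=O)c2cc(F)c(N3CCNCC3)nc21` share most of their framework; the difference between the two cores is not broken down here. In a functional assay on PC-3 cells (Homo sapiens) for cytotoxicity, read by sulforhodamine B assay, with a stated time of 48 h (on this read-out lower numbers stand for stronger inhibition and higher numbers for weaker inhibition), compound 1 gives > 10000 nM, which is a limit of the assay rather than a number. In this assay compound 2 gives > 10000 nM, again a limit and not a number.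

Compound 3 `CCn1cc(-c2nc3ccc(N)cc3[nH]2)c(=O)c2cc(F)c(N3CCNCC3)cc21` arises from compound 1 by the change (amino in place of hydrogen on an aromatic carbon). In this assay compound 3 gives > 10000 nM, which is also a limit. The step that the two limits leave unreadable from compound 1 to compound 3 therefore cannot be sized: both ends sit at the limit of > 10000 nM in this assay, at which 3 of the 3 values shown sit, and nothing measured in this set leaves that limit.

Compound 4 `CCn1cc(-c2nc3ccc(N)cc3[nH]2)c(=O)c2cc(F)c(N3CCNCC3)nc21` stands to compound 2 as compound 3 stands to compound 1: the change amino in place of hydrogen on an aromatic carbon is the same change, made on the other core. Since the identical change on the core of compound 1 gave no readable movement in this assay because both values sit at the limit of > 10000 nM in this assay, at which 3 of the 3 values shown sit, and since compound 2 itself starts at that same limit, the expected outcome is that compound 4 likewise returns a limit rather than a number. The step that this expectation means is estimated as a step that the limit leaves unreadable from compound 2 to compound 4, with the note that it rests on three limits and no measured number. Compound 4 is accordingly estimated at 15000 nM, with a range from 6000 nM to 40000 nM.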

Compound 4, half-maximal inhibitory concentration: > 10000 nM
Compound 4 was reported as a limit; the forecaster's own chance of this, stated with the estimate: 85%; the middle value does not contradict the limit.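

Compound 4 sits at the same limit as compound 2 in this assay, so no step can be read between them, and the entry for each compound is a limit and not a number: the limit of > 10000 nM in this assay, at which 4 of the 4 values shown sit.

The compounds shown leave open whether amino in place of hydrogen on an aromatic carbon, or the difference between the two cores, moves the read-out at all in this assay.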